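Phenyl for methyl on the shared core, against three limits

This account rests on a few compounds, and the source may have more. Where it says the series, first, only, none or still open, it means among the compounds named here.

Compound 1 `Cc1c[se]c(NNC(=O)c2ccccc2)n1`: > 89200 nM
Compound 2 `O=C(NNc1nc(-c2ccccc2)c[se]1)c1ccccc1`: > 73000 nM
Compound 3 `Cc1c[se]c(NNC(=O)c2ccc(Cl)cc2)n1`: > 79400 nM

In a functional assay on HepG2 cells (Homo sapiens) for cytotoxicity, read by XTT assay, with a stated time of 72 h (a higher number here means a weaker inhibitor, a lower number a stronger inhibitor), compound 1 reaches only a limit, > 89200 nM, and no number. Compound 2 likewise gives only a limit, > 73000 nM. Compound 3 also stops at a limit, > 79400 nM, so it stands nowhere in particular among the values shown: every one of the three is a limit, and none can be ordered against another.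

The unmeasured compound 4 `O=C(NNc1nc(-c2ccccc2)c[se]1)c1ccc(Cl)cc1` arises from compound 3 by a single change, (phenyl in place of methyl on an aromatic carbon). The same change has been made once before, on compound 1, and the outcome is a step that the two limits leave unreadable from compound 1 to compound 2, because both ends sit at limits the limit of > 89200 nM in this assay, at which 1 of the 3 values shown sits, and (the limit of > 73000 nM in this assay, at which 1 of the 3 values shown sits). The other measured step, a step that the two limits leave unreadable from compound 1 to compound 3, is equally silent, with compound 3 resting at the limit of > 79400 nM in this assay, at which 1 of the 3 values shown sits. Among the measured compounds shown here, nothing in these numbers points in either direction; the one comparable step gave a limit on both sides.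

Compound 4 is therefore expected to return a limit again in this assay, and the estimated step that the limit leaves unreadable from compound 3 to compound 4 is expected to be nothing beyond the scatter. The estimate for compound 4 is 90000 nM, with a range from 30000 nM to 300000 nM.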

Compound 4, half-maximal inhibitory concentration: 62900 nM
Compound 4: the middle estimate sits 1.4-fold (0.16 log units) above what was measured, and the stated range covers the measured number.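

In this assay compound 4 is the only one of the four compounds shown that gives a number rather than a limit, 62900 nM, and the steps from compound 1 cannot be read. With the chloro group in place, phenyl in place of methyl at the carbon next to the ring nitrogen gives an at least 1.2-fold lower number from compound 3 to compound 4 (0.10 log units; that floor lies within the scatter), so this change now has a floor that can be read, though that floor lies within the scatter. Chloro in place of hydrogen on an aromatic carbon, with the phenyl present, gives an at least 1.1-fold lower number from compound 2 to compound 4 (0.06 log units; that floor lies within the scatter), again a floor within the scatter, so a number appears only where both groups stand together, and neither change is shown to do more than that.

On these data alone, the full size of the phenyl step stays open because compound 3 rests at a limit: the limit of > 79400 nM in this assay, at which 1 of the 4 values shown sits. Also open is whether an amine or a carboxylic acid on the added phenyl, or a longer chain such as propyl in its place, would shift the number in this assay.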